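A few compounds are considered here, and "the series" means these few. Any claim that something is new, unique, unknown or untested is made for them only; others in the source may bear on it.

Compound 1 `COc1ccc(/C=C/c2nc(NCCN3CCCCC3)c3ccccc3n2)cc1OC`: 82700 nM
Compound 2 `CC(C)N(CCNc1nc(/C=C/c2ccc([N+](=O)[O-])cc2)nc2ccccc12)C(C)C`: > 100000 nM

Both results come from a functional assay on A549 cells (Homo sapiens) for cytotoxicity, read by MTT assay, with stated times of 48 h and 4 h; a lower number here means a stronger inhibitor, a higher number a weaker inhibitor. Compound 2 reads > 100000 nM, which is a limit of the assay and not a number. Its standing on the scale is therefore given only by the limit of > 100000 nM in this assay, at which 1 of the 2 values shown sits.

Compound 3 `O=[N+]([O-])c1ccc(/C=C/c2nc(NCCN3CCCCC3)c3ccccc3n2)cc1` has not yet been measured. It differs from compound 2 in a single place: piperidin-1-yl in place of diisopropylamino on a saturated chain carbon, two bonds along the chain from a nitrogen on an aromatic ring. In short, this puts piperidin-1-yl in place of diisopropylamino on a saturated chain carbon, two bonds along the chain from a nitrogen on an aromatic ring.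

Going by the values given here, no pair of measured compounds shows this change alone, so its size has to be judged indirectly. The same piperidin-1-yl group is present in compound 1, which gives 82700 nM in this assay. On that single value, a small shift towards stronger inhibition is expected, and it may not exceed the usual scatter. The expected change is an at least 1.4-fold lower number from compound 2 to compound 3 (0.15 log units; that floor lies within the scatter). A result reported only as a limit also remains possible. The estimate for compound 3 is 70000 nM, with an expected range from 30000 nM to 140000 nM.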

Compound 3, half-maximal inhibitory concentration: 28200 nM
For compound 3 the middle estimate is 2.5-fold (0.39 log units) above the measured one, and the stated range ends above it.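

In this assay, going by these compounds alone, the group at the end of the chain clearly matters: with 4-nitrophenyl held fixed, piperidin-1-yl in place of diisopropylamino gives an at least 3.5-fold lower number from compound 2 to compound 3 (0.54 log units; beyond the scatter), the first direct reading of this change. The true size of that step stays open on one side, since compound 2 is reported only as a limit of the assay and not as a number: the limit of > 100000 nM in this assay, at which 1 of the 3 values shown sits.

With piperidin-1-yl held fixed, the group on the double-bonded chain carbon also counts, as 4-nitrophenyl in place of 3,4-dimethoxyphenyl gives a 2.9-fold lower number from compound 1 to compound 3 (0.47 log units; beyond the scatter), so each of the two changes moves the number by more than the usual scatter.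

The compounds shown compare only two groups at the end of the chain, so it remains open whether morpholin-4-yl or dimethylamino on the same chain would give a lower or a higher number. Also open, as far as these compounds go, is whether a longer chain carrying piperidin-1-yl, or 4-aminophenyl in place of 4-nitrophenyl, would shift the number further.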